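Lengthening an Ester Side Chain: Expected Effect on Binding

The compounds below may be only part of what the source reports. "The series", "measured", "known", "first", "only" and "open" are said of these compounds alone.

Of the compounds shown here, two have been measured in an assay on isolated protein (strain albino) for antagonist activity at Voltage-dependent L-type calcium channel subunit alpha-1C (Cavia porcellus); on this read-out higher numbers stand for weaker inhibition and lower numbers for stronger inhibition. Compound 1 `CSc1ncc(C2C(C(=O)OCCCc3ccccc3)=C(C)NC(C)=C2C(=O)OCCCc2ccccc2)n1Nc1ccccc1` carries two identical esters, each a (3-phenylpropoxy)carbonyl group, and in this assay compound 1 gives 3.15 nM. Compound 2 `COC(=O)C1=C(C)NC(C)=C(C(=O)OCc2ccccc2)C1c1cnc(SC)n1Nc1ccccc1` instead pairs a methyl ester with a benzyloxycarbonyl group; in this assay compound 2 gives 2.21 nM. These two numbers sit within the usual scatter of each other, so no order between the two compounds can be read from them. Compound 3 `COC(=O)C1=C(C)NC(C)=C(C(=O)OCCCc2ccccc2)C1c1cnc(SC)n1Nc1ccccc1` has not been measured. It differs from compound 2 in a single place: phenethyl in place of phenyl on a saturated chain carbon bound to an oxygen next to a carbonyl group. Compound 1 already carries this longer chain on both of its esters and gives 3.15 nM, a number within the scatter of compound 2, so the change is expected to produce no step beyond the scatter. For compound 3 the expected step is a 1.1-fold higher number from compound 2 to compound 3 (0.05 log units; within the scatter), which means an estimated value of 2.5 nM with a likely range from 1 nM to 6 nM.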

Compound 3, half-maximal inhibitory concentration: 3.05 nM
The estimate for compound 3 lay 1.2-fold (0.09 log units) below the measured number, and the stated range covers the measured number.
By their numbers in this assay, from the lowest: compounds 2, 3 and 1 (each within the scatter of the next).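

In this assay, the change from benzyl to 3-phenylpropyl on one ester, with the methyl ester kept, gives a 1.4-fold higher number from compound 2 to compound 3 (0.14 log units; within the scatter), so this chain extension alone makes no readable difference. The other ester can now be judged alone as well: hydrogen in place of phenethyl on a saturated chain carbon bound to an oxygen next to a carbonyl group, which turns a 3-phenylpropyl ester into a methyl ester, gives a 1.0-fold lower number from compound 1 to compound 3 (0.01 log units; within the scatter), again no readable difference. Compounds 1 and 2 differ at both esters, so only compound 3 separates the two changes.

No supporting measurement bears on why the numbers stay so close. Still open, as far as these compounds go, is whether a longer chain than 3-phenylpropyl, or an amine or a carboxylic acid on this chain, would produce a step beyond the scatter.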